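From 2-Hydroxyphenyl to 4-Nitrophenyl on the Carbonyl

This account rests on a few compounds, and the source may have more. Where it says the series, first, only, none or still open, it means among the compounds named here.

Three measured compounds share one core and differ only in the aryl group attached to the carbonyl carbon of the side chain. In an ADME assay on Vero cells (Chlorocebus sabaeus) for cytotoxicity, read by MTT assay, with a stated time of 72 h (a higher number here means that more compound is tolerated, a lower number that less compound is tolerated), compound 1 `COC(=O)c1cc(-c2cccc(NC(=O)c3ccc(/C=C/C(=O)c4cccnc4)cc3)c2)on1` gives "not determined" (no result reported). Compound 2 `COC(=O)c1cc(-c2cccc(NC(=O)c3ccc(/C=C/C(=O)c4ccc(Cl)cc4Cl)cc3)c2)on1` gives > 40 ug/mL in this assay, and that figure is a limit of the assay rather than a number. For the measured compounds named here, compound 3 `COC(=O)c1cc(-c2cccc(NC(=O)c3ccc(/C=C/C(=O)c4ccccc4O)cc3)c2)on1` gives "not determined" (no result reported) in this assay, so it stands nowhere on the numbers: no value of its own, and no step to a measured neighbour can be drawn from it.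

Compound 4 `COC(=O)c1cc(-c2cccc(NC(=O)c3ccc(/C=C/C(=O)c4ccc([N+](=O)[O-])cc4)cc3)c2)on1` is the next member. The change from compound 3 is 4-nitrophenyl in place of 2-hydroxyphenyl on a carbonyl carbon.

No step between measured compounds exists in this set, so the size of the step from compound 3 to compound 4 in this assay cannot be read from any measured pair; on the little that is shown, no shift beyond the usual scatter is expected in either direction.

Compound 4 is therefore estimated at about 40 ug/mL in this assay, with a range from 20 ug/mL to 80 ug/mL, and most probably as a limit again; this expectation rests on (the limit of > 40 ug/mL in this assay, at which 1 of the 3 values shown sits).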

Compound 4, half-maximal cytotoxic concentration: > 20 ug/mL
Compound 4 was reported as a limit; the forecaster's own chance of this, stated with the estimate: 70%; the middle value lies beyond the limit too.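

In this assay compound 4 gives > 20 ug/mL, which is a limit of the assay. Compound 2 also carries only a limit, so no step can be read between compound 2 and compound 4. The compounds shown leave open where the half-maximal cytotoxic concentration of either compound lies, and whether exchanging the aryl group on the carbonyl carbon shifts it at all.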